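This account rests on a few compounds, and the source may have more. Where it says the series, first, only, none or still open, it means among the compounds named here.

In an ADME assay on a cell-free system (plasma, Rattus norvegicus) for protein binding, compound 1 (`CNc1nccc(N2CC[C@H](NC(=O)Nc3ccc(CN(C)C)c(C(F)(F)F)c3)C2)n1`) gives 91%. This lies within the scatter of both other measured compounds: compound 2 (`CNc1nccc(N2CC[C@H](NC(=O)Nc3cccc(C#N)c3)C2)n1`) gives 91.6% and compound 3 (`CNc1nccc(N2CC[C@H](NC(=O)Nc3ccc(OC)cc3)C2)n1`) gives 86.3%. Compound 4 (`CNc1nccc(N2CC[C@H](NC(=O)Nc3ccc(Cl)c(C(F)(F)F)c3)C2)n1`) shares the core of compound 1 and has chloro in place of (dimethylamino)methyl on an aromatic carbon, ortho to a trifluoromethyl group: chloro in place of (dimethylamino)methyl on an aromatic carbon.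

Among the compounds with values here, no measured step makes this change. Within the data shown here, the only step available concerns a different substitution, 4-methoxyphenyl in place of 3-cyanophenyl on an amide-type nitrogen, and it stays within the scatter: a 1.6-fold higher unbound fraction from compound 2 to compound 3 (0.21 log units; within the scatter). Compound 2 also carries no (dimethylamino)methyl, and its 91.6% is within the scatter of compound 1, so a large step is not expected. The direction is only weakly supported by these data. The expected step is a 1.5-fold lower unbound fraction from compound 1 to compound 4 (0.18 log units; within the scatter), toward more bound compound and not beyond the scatter. For compound 4 the estimated value is 94%, with an expected range of 89% to 97.5%.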

Compound 4, plasma protein binding: 99.7%
Compound 4: the middle estimate sits 20-fold (1.30 log units) (unbound fraction) above what was measured; the measured number lies above the stated range.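

In this assay, within the data shown here, the place ortho to a trifluoromethyl group proves highly sensitive to the group it carries: the change gives a 30-fold lower unbound fraction from compound 1 to compound 4 (1.48 log units; beyond the scatter), whereas the only earlier step, a 1.6-fold higher unbound fraction from compound 2 to compound 3 (0.21 log units; within the scatter), gave no sign of a change of this size. The shared core stays the same, so the whole step belongs to this one place, where chloro, with its single heavy atom, replaces the four heavy atoms of (dimethylamino)methyl. Nothing available bears on the cause of this step.

The compounds shown do not separate the loss of (dimethylamino)methyl from the gain of chloro. From the compounds shown here alone, whether a methyl, a fluoro or a carboxylic acid at this place would read like compound 1 or like compound 4 also stays open.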